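Amide heteroaryl swap in sulfonyl benzylamides: stability notes

This account rests on a few compounds, and the source may have more. Where it says the series, first, only, none or still open, it means among the compounds named here.

Measured so far in an ADME assay on microsomes from liver (Mus musculus) for metabolic stability, read by LC-MS, with a stated time of 30 min, tested at 1 uM; on this read-out higher numbers stand for a more stable compound and lower numbers for a less stable compound:
- compound 1 `O=C(NCc1ccc(S(=O)(=O)c2ccccc2)cc1)c1nc2ccncc2s1`: 26%
- compound 2 `O=C(NCc1ccc(S(=O)(=O)N2CCCCC2)cc1)c1cc2ccncc2[nH]1`: "below limit of detection" (no number reported)
- compound 3 `O=C(NCc1ccc(S(=O)(=O)N2CCCCC2)cc1)c1cnc2nccn2c1`: 0.28%

Compound 1 is the more stable of the two compounds that returned a number. Compound 3 sits well lower, with 0.28%, while compound 1 gives 26%, a gap beyond the scatter. For compound 2 the read-out is a limit of this assay, not a number, so it cannot be ranked against the other two.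

Compound 4 `O=C(NCc1ccc(S(=O)(=O)c2ccccc2)cc1)c1cc2cnccc2[nH]1` is not yet measured. It differs from compound 1 in one place, on the carbonyl carbon whose other neighbour is the amide-type nitrogen: a group of 9 heavy atoms (7 carbon, 2 nitrogen; one five-membered aromatic ring with 1 hetero atom, one six-membered aromatic ring with 1 hetero atom) in place of a group of 9 heavy atoms (6 carbon, 2 nitrogen, 1 sulfur; one five-membered aromatic ring with 2 hetero atoms, one six-membered aromatic ring with 1 hetero atom), on a carbonyl carbon

Among the compounds with values here, no step between two measured compounds covers this exchange, so the size of the change in this assay is open. Within the data shown here, the only compound carrying a ring pair of this kind, compound 2, gave a read-out that was a limit, and its sulfonyl part is not that of compound 1, so it is a weak guide. On balance a downward step is expected, a number 12 percentage points lower from compound 1 to compound 4 (beyond the scatter), of moderate size and likely beyond the scatter. Compound 4 is accordingly estimated at 14%, with a range from 3% to 32%.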

Compound 4, percent of the compound remaining: 54%
Beside the measured number, compound 4's estimate is 40 percentage points below it, outside the stated range (above it).
By their numbers in this assay, from the lowest: compound 3; then compound 1; then compound 4.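

In this assay, the place on the carbonyl carbon whose other neighbour is the amide-type nitrogen now has its first readable step, a number 28 percentage points higher from compound 1 to compound 4 (beyond the scatter), so this position can shift the read-out even when the heavy-atom count and the ring sizes stay the same. The sulfur-containing group of compound 1 is therefore not required for the higher number within this pair: the entering group has no sulfur and has 1 hydrogen-bond donor and 1 hydrogen-bond acceptor, against 0 donors and 3 acceptors in the leaving group. No supporting data are available to show which of these differences accounts for the step.

This single step, on the sulfonyl part shared by compound 1 and compound 4, does not show whether the exchange would act in the same direction on the different sulfonyl part carried by compound 2 and compound 3. Also open, as far as these compounds go, is how this position would respond to a simpler group at the same place, such as a plain phenyl ring or a carboxylic acid.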